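Swapping tert-butyl for fluoro on a weakly cytotoxic urea

A few compounds are considered here, and "the series" means these few. Any claim that something is new, unique, unknown or untested is made for them only; others in the source may bear on it.

Compound 1 `Cc1cc(NC(=O)Nc2ccccc2C(C)(C)C)c2ccccc2n1` is a urea linking a shared core to a phenyl ring carrying a tert-butyl group. Going by the values given here, in an ADME assay on BJ cells (Homo sapiens) for cytotoxicity, with a stated time of 72 h (on this read-out lower numbers stand for an effect already at smaller amounts and higher numbers for an effect only at larger amounts of compound), compound 1 gives 22000 nM, the only measured number among the three compounds examined. Compound 2 `Cc1cc(NC(=O)Nc2ccc(N(C)C)cc2)c2ccccc2n1` carries a dimethylamino group instead, and in this assay compound 2 gives > 25000 nM, which is a limit of the assay rather than a number. Compound 3 `Cc1cc(NC(=O)Nc2ccc(SC(F)(F)F)cc2)c2ccccc2n1` carries a (trifluoromethyl)sulfanyl group, and in this assay compound 3 gives > 25000 nM, again a limit. The step that the two limits leave unreadable from compound 2 to compound 3 is therefore not readable.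

Compound 4 `Cc1cc(NC(=O)Nc2ccccc2F)c2ccccc2n1` differs from compound 1 by fluoro in place of tert-butyl on an aromatic carbon. Among the compounds with values here, no measured step involves this change, so the expectation rests on the pattern of the values themselves: because of the limit of > 25000 nM in this assay, at which 2 of the 3 values shown sit, compound 4 is expected near or beyond that limit. The estimated step of a 1.1-fold higher number from compound 1 to compound 4 (0.06 log units; within the scatter) is expected to be small, within the scatter or slightly weaker. Compound 4 is estimated at 25000 nM, between 12000 nM and 60000 nM.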

Compound 4, half-maximal effective concentration: > 25000 nM
Compound 4: only a limit was reported (the forecaster's own chance of this, stated with the estimate: 60%); the middle value sits exactly at the limit.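

Swapping tert-butyl for fluoro on this aromatic carbon gives the first comparison that starts from the only measured number in the set: an at least 1.1-fold higher number from compound 1 to compound 4 (0.05 log units; that floor lies within the scatter). In this assay compound 4 gives > 25000 nM, which is a limit of the assay and not a number. Going from the larger group to a single fluorine atom therefore did not bring the effect to clearly smaller amounts of compound, but how far the number rises cannot be read, and most of the set now sits at one edge of the scale: the limit of > 25000 nM in this assay, at which 3 of the 4 values shown sit.

As far as these compounds go, it remains open whether tert-butyl itself is what sets compound 1 apart from the compounds that give only a limit. An amine, a carboxylic acid or a methoxy group on this same carbon could help to answer that.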